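This account rests on a few compounds, and the source may have more. Where it says the series, first, only, none or still open, it means among the compounds named here.

Working notes on the series. Compound 1 `Oc1cccc(-c2cc(-c3ccccc3F)cc(-c3ccccc3O)n2)c1` gives 24200 nM in a functional assay on T47D cells (Homo sapiens) for inhibition; on this read-out lower numbers stand for stronger inhibition and higher numbers for weaker inhibition. Compound 3 `Oc1cccc(-c2cc(-c3ccccc3C(F)(F)F)cc(-c3ccccc3O)n2)c1` gives 5680 nM in this assay and holds the lowest of the two numbers obtained; its nearest neighbour is compound 1, with a 4.3-fold lower number from compound 1 to compound 3 (0.63 log units; beyond the scatter). Compound 2 `Oc1cccc(-c2cc(-c3cccc(F)c3)cc(-c3ccccc3O)n2)c1` reaches only the limit of > 50000 nM in this assay, which is a limit and not a number, as the limit of > 50000 nM in this assay, at which 1 of the 3 values shown sits, records. The step from 2-fluorophenyl to 3-fluorophenyl, an at least 2.0-fold higher number from compound 1 to compound 2 (0.31 log units; beyond the scatter), therefore ran toward weaker inhibition, though its full size is hidden by the limit. The gap an at least 8.8-fold lower number from compound 2 to compound 3 (0.94 log units; beyond the scatter) combines that move with the exchange of fluoro for trifluoromethyl.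

Compound 4 `Oc1cccc(-c2cc(-c3cccc(C(F)(F)F)c3)cc(-c3ccccc3O)n2)c1` is not yet measured. It differs from compound 3 by 3-(trifluoromethyl)phenyl in place of 2-(trifluoromethyl)phenyl on an aromatic carbon. Among the compounds with values here, the only measured step bearing on this change is the one from compound 1 to compound 2, the same move of the substituent from the 2-position to the 3-position on the pendant phenyl, which gave a number at least modestly higher. The expectation for compound 4 is accordingly a higher number than compound 3, a 3.5-fold higher number from compound 3 to compound 4 (0.55 log units; beyond the scatter), with a real chance that only a limit results. The estimated value for compound 4 in this assay is 20000 nM, within a range from 7000 nM to 60000 nM.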

Compound 4, half-maximal inhibitory concentration: 6340 nM
The estimate for compound 4 lay 3.2-fold (0.50 log units) above the measured number; the measured number lies below the stated range.
By their numbers in this assay, from the lowest: compounds 3 and 4 (each within the scatter of the next); then compound 1. At a limit, above all of these: compound 2.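

The move from 2-(trifluoromethyl)phenyl to 3-(trifluoromethyl)phenyl leaves this assay without a readable difference, a 1.1-fold higher number from compound 3 to compound 4 (0.05 log units; within the scatter), whereas the same shift between the fluorophenyl groups gave an at least 2.0-fold higher number from compound 1 to compound 2 (0.31 log units; beyond the scatter), so the effect of this position is not the same for every substituent in the four compounds shown. Compound 4 also stands clear of both fluoro compounds, with a 3.8-fold lower number from compound 1 to compound 4 (0.58 log units; beyond the scatter) and an at least 7.8-fold lower number from compound 2 to compound 4 (0.89 log units; beyond the scatter), so the lower numbers now go with trifluoromethyl at either position and no compound shown goes against this. Trifluoromethyl in place of fluoro has therefore been seen twice, on two cores that differ in where the group sits: the same change on two cores in this assay, a 4.3-fold lower number (0.63 log units; beyond the scatter) from compound 1 to compound 3 and an at least 7.8-fold lower number (0.89 log units; beyond the scatter) from compound 2 to compound 4; the limit leaves it open whether they differ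

On these data alone, compound 2 stands at > 50000 nM, which is a limit of the assay and not a number, so the true size of its steps remains unknown. As far as these compounds go, whether anything other than trifluoromethyl keeps these numbers at both positions stays open, as does what a nitrile, an amine or a carboxylic acid would give in its place in this assay.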